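Second chloro on the aryl ether of compound 2

This account rests on a few compounds, and the source may have more. Where it says the series, first, only, none or still open, it means among the compounds named here.

In a functional assay for agonist activity at Free fatty acid receptor 1 (Homo sapiens), read by FLIPR, in the presence of a further agent that is not named here (a lower number here means that less compound is needed, a higher number that more compound is needed for the effect), compound 1 `Cc1ccccc1Oc1ccc(CC2SC(=O)NC2=O)cc1` gives 124 nM, compound 2 `O=C1NC(=O)C(Cc2ccc(Oc3cccc(Cl)c3)cc2)S1` gives 318 nM, and compound 3 `Cc1ccc(Oc2ccc(CC3SC(=O)NC3=O)cc2)cc1` gives 547 nM. Compound 2 thus stands second highest of the three, with a 1.7-fold higher number from compound 2 to compound 3 (0.24 log units; within the scatter) and a 2.6-fold higher number from compound 1 to compound 2 (0.41 log units; beyond the scatter). Compound 4 `O=C1NC(=O)C(Cc2ccc(Oc3cc(Cl)cc(Cl)c3)cc2)S1` differs from compound 2 by chloro in place of hydrogen on an aromatic carbon. Among the compounds with values here, no measured step adds a group to an already substituted aryl ether; the steps of a 2.6-fold higher number from compound 1 to compound 2 (0.41 log units; beyond the scatter) and a 4.4-fold higher number from compound 1 to compound 3 (0.64 log units; beyond the scatter) only exchange one aryl group for another and are modest. He therefore expects for compound 4 no step beyond the scatter in this assay, that is a 1.0-fold higher number from compound 2 to compound 4 (0.00 log units; within the scatter). His estimate for compound 4 is 320 nM, within 110 nM to 950 nM.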

Compound 4, half-maximal effective concentration: 207 nM
Estimate against measurement, compound 4: 1.5-fold (0.19 log units) above; the range from low to high includes it.
By their numbers in this assay, from the lowest: compounds 1, 4, 2 and 3 (each within the scatter of the next, the first and the last beyond it).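

In this assay, chloro in place of hydrogen on an aromatic carbon, meta to a chloro group, gives a 1.5-fold lower number from compound 2 to compound 4 (0.19 log units; within the scatter) and so leaves the number unchanged within the scatter. This is the first step shown that adds a group to an already substituted aryl ether instead of exchanging one aryl group for another. Nothing available explains this result.

Going by these compounds, whether methoxy or a carboxylic acid at this place would also leave the number unchanged remains open. So does whether added chloro would behave alike on the aryl ethers of compound 1 and compound 3.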